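This account rests on a few compounds, and the source may have more. Where it says the series, first, only, none or still open, it means among the compounds named here.

Of the compounds shown here, two of a shared core have been measured in a physicochemical assay for solubility, read by spectrophotometry, in phosphate buffer, with a stated time of 2 h, at pH 7.4; a lower number here means a less soluble compound, a higher number a more soluble compound. Compound 1, `COc1ccc2[nH]c(C(=O)N3CC(=O)N(Cc4ccc[nH]4)[C@@H](Cc4ccccc4)C3)cc2c1`, gives 38400 nM in this assay. Compound 2, `COc1ccc2[nH]c(C(=O)N3CC(=O)N(Cc4ccccc4)[C@@H](COc4ccc(F)cc4)C3)cc2c1`, gives 17500 nM in this assay, the lowest of the two numbers: compound 1 stands at a higher number, a gap beyond the scatter. For the measured compounds named here, no pair of measured compounds differs in only one place, so no measured step is available to lean on.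

Compound 3, `COc1ccc2[nH]c(C(=O)N3CC(=O)N(Cc4ccccc4)[C@@H](CN4CCCc5ccccc54)C3)cc2c1`, is the next compound to be measured. It differs from compound 2 in one place: 1,2,3,4-tetrahydroquinolin-1-yl in place of 4-fluorophenoxy on a saturated chain carbon bound to a saturated ring carbon. The change keeps the count of hydrogen-bond donors and acceptors unchanged while adding two heavy atoms and a second ring.

Without a measured step of this kind, the expectation rests on the size of the change alone; a modest drop in this assay is expected, of about a 1.9-fold lower number from compound 2 to compound 3 (0.29 log units; within the scatter). Compound 3 is therefore estimated at 9000 nM, with a range from 3000 nM to 27000 nM.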

Compound 3, solubility: 8500 nM
Compound 3: the middle estimate sits 1.1-fold (0.02 log units) above what was measured; measured number inside the range.
By their numbers in this assay, from the lowest: compound 3; then compound 2; then compound 1.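

For the compounds shown here, this is the first measured step at this position: on a saturated chain carbon bound to a saturated ring carbon, 1,2,3,4-tetrahydroquinolin-1-yl in place of 4-fluorophenoxy gives a 2.1-fold lower number from compound 2 to compound 3 (0.31 log units; beyond the scatter) in this assay. The group on this carbon can therefore shift the read-out by a modest amount, even with the count of hydrogen-bond donors and acceptors unchanged. Nothing measured here says what lies behind this step.

As far as these compounds go, with a single step, it stays open which part of the exchange matters: the loss of the fluorine, the change of the linking atom from oxygen to nitrogen, or the second ring. Plain phenoxy or piperidin-1-yl on the same carbon would each change fewer of these parts at once.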